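This account rests on a few compounds, and the source may have more. Where it says the series, first, only, none or still open, it means among the compounds named here.

Measured in a functional assay on MCF7 cells (Homo sapiens) for cytotoxicity, read by MTT assay, with a stated time of 72 h; a lower number here means a stronger inhibitor, a higher number a weaker inhibitor:
Compound 1 `CC(C)[S+]([O-])CCCCN=C=S`: 8820 nM
Compound 2 `[O-][S+](CCCCN=C=S)Cc1ccccc1`: 3300 nM

Of these two, compound 2 has the lower number at 3300 nM, and compound 1, at 8820 nM, lies above it beyond the scatter. Compound 3 `COc1ccc(C[S+]([O-])CCCCN=C=S)cc1` differs from compound 2 in one place: methoxy in place of hydrogen on an aromatic carbon. For the measured compounds named here, no measured pair shows the effect of such a change, so no step beyond the scatter is expected in this assay. The estimated step is a 1.1-fold lower number from compound 2 to compound 3 (0.04 log units; within the scatter). For compound 3 the expected value is 3000 nM, with an estimated range from 1300 nM to 7000 nM.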

Compound 3, half-maximal inhibitory concentration: 8890 nM
Estimate against measurement, compound 3: 3.0-fold (0.47 log units) below, outside the stated range (above it).
By their numbers in this assay, from the lowest: compound 2; then compounds 1 and 3 (each within the scatter of the next).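

In this assay methoxy in place of hydrogen on an aromatic carbon, para to a large group, gives a 2.7-fold higher number from compound 2 to compound 3 (0.43 log units; beyond the scatter), a modest step beyond the scatter. This shows that the ring position is not indifferent to substitution and that this change weakens inhibition, which compounds 1 and 2 alone could not show. Nothing available accounts for the step. The compounds shown leave open whether this step is particular to methoxy or would also follow from a fluorine, a chlorine or a hydroxyl at this place.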